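The compounds below may be only part of what the source reports. "The series", "measured", "known", "first", "only" and "open" are said of these compounds alone.

Compound 1 `CCCCCCCC(=O)OCC(C)(C)CC1=C(O)C(=O)c2ccccc2C1=O`, compound 2 `CCCCCCCCCC(=O)OCC(C)(C)CC1=C(O)C(=O)c2ccccc2C1=O` and compound 3 `CCCCCCCCCCCCCC(=O)OCC(C)(C)CC1=C(O)C(=O)c2ccccc2C1=O` share one core and differ only in the length of a saturated chain carried by an ester. In an ADME assay on Vero cells (Chlorocebus sabaeus) for cytotoxicity, read by MTT assay (on this read-out higher numbers stand for weaker inhibition and lower numbers for stronger inhibition), compound 1 gives only a limit, > 258000 nM, and no number (the limit of > 258000 nM in this assay, at which 1 of the 3 values shown sits). In this assay compound 2 gives 203000 nM, and compound 3 gives 58400 nM. The change from compound 1 to compound 2 is ethyl in place of hydrogen on a saturated chain carbon, seven bonds along the chain from a carbonyl carbon, and it brought an at least 1.2-fold lower number from compound 1 to compound 2 (0.10 log units; that floor lies within the scatter). The cores of compound 1 and compound 3 differ by hexyl in place of hydrogen on a saturated chain carbon, seven bonds along the chain from a carbonyl carbon, which brought an at least 4.4-fold lower number from compound 1 to compound 3 (0.64 log units; beyond the scatter); between the two longer chains there was a 3.5-fold lower number from compound 2 to compound 3 (0.54 log units; beyond the scatter).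

Compound 4 `CCCCCCCCCCCCCCCC(=O)OCC(C)(C)CC1=C(O)C(=O)c2ccccc2C1=O` has not yet been measured. Its change from compound 3 is ethyl in place of hydrogen on a saturated chain carbon, ten or more bonds along the chain from a carbonyl carbon. This is the same kind of change as that from compound 1 to compound 2, though the place on the chain where the ethyl enters differs, as the two descriptions of the change show. Because the lengthening to compound 3 gave a 3.5-fold lower number from compound 2 to compound 3 (0.54 log units; beyond the scatter), the step from compound 3 to compound 4 is expected to be a 1.9-fold lower number from compound 3 to compound 4 (0.29 log units; within the scatter). Compound 4 is therefore estimated at 30000 nM, with a likely range from 12000 nM to 70000 nM.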

Compound 4, half-maximal inhibitory concentration: 4410 nM
Compound 4: the middle estimate sits 6.8-fold (0.83 log units) above what was measured; the measured number lies below the stated range.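

Lengthening the saturated chain on the ester ends, in this series, at compound 4, whose number in this assay lies beyond the scatter of all three shorter chains, with a 13-fold lower number from compound 3 to compound 4 (1.12 log units; beyond the scatter), a 46-fold lower number from compound 2 to compound 4 (1.66 log units; beyond the scatter) and an at least 58-fold lower number from compound 1 to compound 4 (1.76 log units; beyond the scatter). Ethyl in place of hydrogen appears at two places along the chain, and this does not show that the change carries over with one size from one core to another: the same change on two cores in this assay, an at least 1.2-fold lower number (0.10 log units; that floor lies within the scatter) from compound 1 to compound 2 and a 13-fold lower number (1.12 log units; beyond the scatter) from compound 3 to compound 4; the limit leaves it open whether they differ. The hexyl change stays just as unsettled, and both comparisons rest on compound 1, which gives a limit and not a number: the same change on two cores in this assay, an at least 4.4-fold lower number (0.64 log units; beyond the scatter) from compound 1 to compound 3 and a 46-fold lower number (1.66 log units; beyond the scatter) from compound 2 to compound 4; the limit leaves it open whether they differ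

The compounds shown leave open whether a longer chain would lower the number further or whether the trend would stop. They also leave open whether an amine or a carboxylic acid at the far end of the chain, or an amide in place of the ester, would fit the same trend.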